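The source may report more compounds than this note shows. Statements on the series, on what has been measured and on what is new or still open speak of the compounds shown alone.

Compound 2, with structure `Cc1ccccc1-n1nc(C)c2c1NC(=O)[C@H](C)S[C@@H]2c1ccc(/C=C/c2ccccc2)cc1`, was tested in an assay on isolated protein for agonist activity at Bile acid receptor (Homo sapiens), read by AlphaScreen, with a stated time of 30 min (a higher number here means that more compound is needed for the effect, a lower number that less compound is needed), and compound 2 gave "not active" (no number reported): no single number was recorded for it, so no value can be placed on a scale for it. Two related compounds do carry numbers. Compound 1, `COc1ccc(Oc2ccc([C@H]3S[C@@H](C)C(=O)Nc4c3c(C)nn4-c3ccccc3C)cc2)cc1`, gives 2200 nM in this assay, and compound 3, `Cc1nn(-c2ccccc2C(C)C)c2c1[C@@H](c1ccc(Oc3ccccc3)cc1)S[C@@H](C)C(=O)N2`, gives 1900 nM; these two values lie within the usual scatter of each other, so no order between them can be drawn. Compound 4, `COc1ccccc1Oc1ccc([C@H]2S[C@@H](C)C(=O)Nc3c2c(C)nn3-c2ccccc2C)cc1`, has not yet been measured. It differs from compound 2 in one place: 2-methoxyphenoxy in place of 2-phenylethenyl on an aromatic carbon. For the measured compounds named here, no measured step of this kind is available, so the expectation for compound 4 rests on compound 1 and compound 3, which carry the same kind of aryloxy group and gave numbers rather than an inactive call. On that basis compound 4 is expected to move from the inactive result of compound 2 into the measurable range, near the values of compound 1 and compound 3. The half-maximal effective concentration of compound 4 in this assay is estimated at 2500 nM, with a range from 800 nM to 8000 nM.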

Compound 4, half-maximal effective concentration: 1700 nM
Compound 4: the middle estimate sits 1.5-fold (0.17 log units) above what was measured; the range from low to high includes it.
By their numbers in this assay, from the lowest: compounds 4, 3 and 1 (each within the scatter of the next).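

In this assay, 2-methoxyphenyl in place of 4-methoxyphenyl on the oxygen gives a 1.3-fold lower number from compound 1 to compound 4 (0.11 log units; within the scatter), so these two arrangements of the methoxy group cannot be told apart here. Compound 2 was called not active, whereas compound 4, with 2-methoxyphenoxy in place of 2-phenylethenyl on the same aromatic carbon, gives 1700 nM as a measured value. For the compounds shown here, at this place, para to a large group, a measurable result therefore holds for both methoxyphenoxy groups, while the single 2-phenylethenyl example has no number. The compounds shown leave open whether a hydroxy group, an aminomethyl group or a carboxylic acid on the outer ring, in place of methoxy, would shift the number beyond the scatter. Nothing available explains why either exchange has the outcome it has.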